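Acetonide in place of the free diol on the triazole arm

A few compounds are considered here, and "the series" means these few. Any claim that something is new, unique, unknown or untested is made for them only; others in the source may bear on it.

Compound 3 `O=C1c2c[n+]([O-])c3ccccc3c2C(=O)c2c1c1ccccc1n2Cc1cn(C[C@@H](O)CO)nn1` gives 190 nM in a functional assay on HCT-116 cells (Homo sapiens) for cytotoxicity, read by MTT assay, with a stated time of 72 h; on this read-out higher numbers stand for weaker inhibition and lower numbers for stronger inhibition. It stands second highest of the three numbers recorded: its nearest neighbour is compound 2 `O=C1c2c[n+]([O-])c3ccccc3c2C(=O)c2c1c1ccccc1n2Cc1cn([C@H]2C[C@H](O)[C@@H](CO)O2)nn1`, which gives 120 nM, a difference that a 1.6-fold higher number from compound 2 to compound 3 (0.20 log units; within the scatter); the furthest is compound 1 `CN1CCN(CCCCCCn2c3c(c4ccccc42)C(=O)c2c[n+]([O-])c4ccccc4c2C3=O)CC1`, which gives 2900 nM, a gap that a 15-fold lower number from compound 1 to compound 3 (1.18 log units; beyond the scatter).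

Compound 4 `CC1(C)O[C@@H](CO)[C@H](Cn2cc(Cn3c4c(c5ccccc53)C(=O)c3c[n+]([O-])c5ccccc5c3C4=O)nn2)O1` carries 5-(hydroxymethyl)-2,2-dimethyl-1,3-dioxolan-4-yl in place of 1,2-dihydroxyethyl on a saturated chain carbon bound to an aromatic nitrogen. Within the data shown here, the only measured step at the same end of the molecule, the one from compound 2 to compound 3, stayed within the scatter although the group on the aromatic nitrogen changed from a ring to a chain. The large step from compound 1 to compound 3 concerns the whole arm and does not bear directly on this smaller change. Among the measured compounds shown here, no measured pair shows what replacing two hydroxyls by a dioxolane with a hydroxymethyl does; the expectation is therefore for a step of a 1.3-fold higher number from compound 3 to compound 4 (0.12 log units; within the scatter) of no size beyond the scatter. Compound 4 is estimated at 250 nM, with a range from 100 nM to 700 nM.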

Compound 4, half-maximal inhibitory concentration: 130 nM
Compound 4: the middle estimate sits 1.9-fold (0.28 log units) above what was measured, and the stated range covers the measured number.
By their numbers in this assay, from the lowest: compounds 2, 4 and 3 (each within the scatter of the next); then compound 1.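

In this assay, masking the diol as 5-(hydroxymethyl)-2,2-dimethyl-1,3-dioxolan-4-yl in place of 1,2-dihydroxyethyl gives a 1.5-fold lower number from compound 3 to compound 4 (0.16 log units; within the scatter), so at this position on a saturated chain carbon bound to an aromatic nitrogen, a five-membered ring and added heavy atoms leave the number within the scatter. The comparison with the sugar-type arm gives a 1.1-fold higher number from compound 2 to compound 4 (0.03 log units; within the scatter), so compound 2, compound 3 and compound 4 cannot be told apart on this read-out, despite three different arms on the triazole. No supporting data bear on why these arms read alike.

Whether the arm stays this permissive with a charged end is open: a carboxylic acid or a 4-methylpiperazin-1-yl group on the triazole could answer that. Also open, as far as these compounds go, is whether the large gap to compound 1 follows from its 4-methylpiperazin-1-yl end or from its longer chain without the triazole.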